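Notes on a series that has so far shown only limits

The compounds below may be only part of what the source reports. "The series", "measured", "known", "first", "only" and "open" are said of these compounds alone.

Measured in an assay on cells for inhibition of Amine oxidase [flavin-containing] A (Homo sapiens), read by Amplex Red, with a stated time of 30 min; a lower number here means a stronger inhibitor, a higher number a weaker inhibitor:
compound 1, `CN1N=C(c2ccc(/N=C/c3cccc(Cl)c3)cc2)OCC1=O`, gives > 100000 nM, a limit of the assay.
compound 2, `O=C1COC(c2ccc(/C=C/c3ccccc3)cc2)=NN1`, gives > 100000 nM, a limit of the assay.
compound 3, `O=C1COC(c2ccc(/C=C/c3cccc(F)c3)cc2)=NN1`, gives > 100000 nM, a limit of the assay.

Going by the values given here, compound 3 therefore stands at the limit of this assay, not at a number, and the same holds for the two other compounds measured so far; all three sit at the limit of > 100000 nM in this assay, at which 3 of the 3 values shown sit. Among the compounds with values here, the one single-point step that is measured, a step that the two limits leave unreadable from compound 2 to compound 3, runs from one limit to another and its size cannot be read. Compound 1, which carries a different linker and a methylated ring nitrogen, adds nothing beyond its own limit.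

The next compound, compound 4, `O=C1COC(c2ccc(/C=C/c3ccc(Cl)cc3)cc2)=NN1`, differs from compound 3 by 4-chlorophenyl in place of 3-fluorophenyl on a double-bonded chain carbon bound to a double-bonded chain carbon. Within the data shown here, no measured step bears on this change in a readable way: the only step available is the unreadable one from compound 2 to compound 3, and it leaves no direction or size to carry forward. The expectation for compound 4 is therefore a step of unknown size, a step that the limit leaves unreadable from compound 3 to compound 4, most likely again ending at the limit. Compound 4 is estimated at 200000 nM in this assay, with a range from 50000 nM to 1000000 nM, and the result is expected to be reported as a limit rather than a number.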

Compound 4, half-maximal inhibitory concentration: > 100000 nM
Compound 4: only a limit was reported (the forecaster's own chance of this, stated with the estimate: 85%); the middle value lies beyond the limit too.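

In this assay compound 4 also gives only a limit of the assay, so neither the step to it from compound 2 nor the step to it from compound 3 can be read: the limit of > 100000 nM in this assay, at which 4 of the 4 values shown sit.

The compounds shown leave open whether any change on the shared core gives a measurable number in this assay, and what direction or size such a step would have.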